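Swapping the fused diamine for an aminocyclohexylamino group

The source may hold more compounds than are shown below. What is called first, only, known or untested is meant among the compounds shown, and "the series" means these compounds.

Measured compounds:
- compound 1 `CN(C[C@H]1Cc2c(cccc2N2C[C@H]3CNC[C@H]3C2)CN1)[C@H]1CCCc2cccnc21`: 10.3 nM
- compound 2 `CN(C)[C@H]1CCN(c2cccc3c2C[C@H](CN(C)[C@H]2CCCc4cccnc42)NC3)C1`: 10.9 nM
- compound 3 `CN(C[C@H]1Cc2c(cccc2N2C[C@H]3CCN(C)[C@H]3C2)CN1)[C@H]1CCCc2cccnc21`: 18.7 nM

All three were tested in a functional assay on CCRF-CEM cells for antagonist activity at C-X-C chemokine receptor type 4 (Homo sapiens), read by calcium flux, with stated times of 25 min and 90 s; a lower number here means a stronger inhibitor, a higher number a weaker inhibitor. Compound 1 gives 10.3 nM and has the lowest number of the three, but its neighbours sit close: a 1.1-fold higher number from compound 1 to compound 2 (0.02 log units; within the scatter) and a 1.8-fold higher number from compound 1 to compound 3 (0.26 log units; within the scatter) are both within the scatter, so none of the three can be called stronger or weaker than the others.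

Compound 4 `CN(C[C@H]1Cc2c(cccc2N[C@H]2CC[C@H](N)CC2)CN1)[C@H]1CCCc2cccnc21` is not yet measured. It differs from compound 1 by a group of 8 heavy atoms (6 carbon, 2 nitrogen; one six-membered non-aromatic ring of carbon only) in place of a group of 8 heavy atoms (6 carbon, 2 nitrogen; 2 five-membered non-aromatic rings with 1 hetero atom each), on an aromatic carbon; the group that leaves has two five-membered non-aromatic rings with one hetero atom each, and the group that enters, (4-aminocyclohexyl)amino, has one six-membered non-aromatic ring of carbon only, on an aromatic carbon ortho to a fused ring and meta to a fused ring.

Among the compounds with values here, the steps that bear on this change are those in which the same position was varied: a 1.1-fold higher number from compound 1 to compound 2 (0.02 log units; within the scatter), a 1.8-fold higher number from compound 1 to compound 3 (0.26 log units; within the scatter) and a 1.7-fold higher number from compound 2 to compound 3 (0.23 log units; within the scatter). Each stayed within the scatter, which suggests this position tolerates different diamine groups. The change to compound 4 is larger in kind than those steps, so some loss beyond them is possible, but no firm direction is supported.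

For compound 4 an expected step of a 2.1-fold higher number from compound 1 to compound 4 (0.33 log units; beyond the scatter) in this assay leads to an estimate of 22 nM, with a range from 6 nM to 80 nM.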

Compound 4, half-maximal inhibitory concentration: 755 nM
For compound 4 the middle estimate is 34-fold (1.54 log units) below the measured one; measured number above the stated range.
By their numbers in this assay, from the lowest: compounds 1, 2 and 3 (each within the scatter of the next); then compound 4.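

The earlier steps shown here made this position look tolerant, but in this assay the (4-aminocyclohexyl)amino group shows a limit to that tolerance, with a 73-fold higher number from compound 1 to compound 4 (1.87 log units; beyond the scatter). The loss does not depend on which earlier compound serves as the reference, since a 69-fold higher number from compound 2 to compound 4 (1.84 log units; beyond the scatter) and a 40-fold higher number from compound 3 to compound 4 (1.61 log units; beyond the scatter) are also large and beyond the scatter. The groups of compound 1 and compound 4 have the same heavy-atom count, so that count alone does not separate a well-tolerated group from a poorly tolerated one, and the earlier agreement among compound 1, compound 2 and compound 3 cannot be extended to every diamine group on this aromatic carbon.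

The compounds shown leave open whether the six-membered ring of carbon only, the nitrogen outside the ring that joins it to the aromatic carbon, or the added hydrogen-bond donor accounts for the difference, and a 4-aminopiperidin-1-yl group, with its ring nitrogen on the aromatic carbon, would help to separate these features. Nothing available here explains the size of this loss.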